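Cytotoxicity with a new aryl group: compound 3 to compound 4

The source may report more compounds than this note shows. Statements on the series, on what has been measured and on what is new or still open speak of the compounds shown alone.

Of the compounds shown here, three have been tested in an ADME assay on BJ cells (Homo sapiens) for cytotoxicity, with a stated time of 72 h; a higher number here means that more compound is needed for the effect, a lower number that less compound is needed. Compound 1 `Cc1nn(-c2ccccc2)c2nc(-c3ccc(C(C)C)cc3)c(C#N)c(-c3ccccc3O)c12` gives 22600 nM, and compound 2 `Cc1nn(-c2ccccc2)c2nc(-c3ccc(I)cc3)c(C#N)c(-c3ccccc3O)c12` gives 19000 nM.

Compound 3 `Cc1nn(-c2ccccc2)c2nc(-c3ccc(C#N)cc3)c(C#N)c(-c3ccccc3O)c12` gives only a limit, > 20000 nM, and no number. This is the one limit among the three results: the limit of > 20000 nM in this assay, at which 1 of the 3 values shown sits.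

Compound 4 `Cc1nn(-c2ccccc2)c2nc(-c3ccc4c(c3)OCCO4)c(C#N)c(-c3ccccc3O)c12` carries 2,3-dihydro-1,4-benzodioxin-6-yl in place of the 4-cyanophenyl of compound 3, on an aromatic carbon next to the ring nitrogen: 2,3-dihydro-1,4-benzodioxin-6-yl in place of 4-cyanophenyl on an aromatic carbon.

The three measured steps all change a group on the phenyl ring at this same carbon, and none replaces the whole ring. The first, a 1.2-fold lower number from compound 1 to compound 2 (0.08 log units; within the scatter), lies within the scatter. The floor of the second, an at least 1.0-fold higher number from compound 2 to compound 3 (0.02 log units; that floor lies within the scatter), also lies within the scatter. The third, a step that the limit leaves unreadable from compound 1 to compound 3, cannot be read through the limit.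

These steps give no reason to expect a change beyond the scatter in this assay, in either direction. The expected step is a number no higher from compound 3 to compound 4 (the limit leaves the size open).

For compound 4 the estimate is 20000 nM, with an expected range of 11000 nM to 36000 nM.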

Compound 4, half-maximal effective concentration: > 20000 nM
Compound 4 was reported as a limit (the forecaster's own chance of this, stated with the estimate: 35%); the middle value lies on the limit itself.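

For the compounds shown here, the change replaces a whole 4-substituted phenyl group at this carbon for the first time, and in this assay compound 4 with its 2,3-dihydro-1,4-benzodioxin-6-yl group also gives a limit and not a number, so the series now holds a second result of this kind: the limit of > 20000 nM in this assay, at which 2 of the 4 values shown sit. Going by these compounds alone, the one readable comparison is only a floor, an at least 1.0-fold higher number from compound 2 to compound 4 (0.02 log units; that floor lies within the scatter), and the steps to compound 4 from compound 1 and from compound 3 cannot be read. The fused ring at this carbon therefore gives no readable change in this assay.

On these data alone, how far compound 3 and compound 4 lie past their limits stays open, so the two cannot be ordered. Also open, as far as these compounds go, is whether an amine or a carboxylic acid on the phenyl ring at this carbon would give a readable number in this assay.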